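The source may hold more compounds than are shown below. What is called first, only, known or untested is meant among the compounds shown, and "the series" means these compounds.

Among the compounds with values here, in a functional assay on SW480 cells (Homo sapiens) for antiproliferative activity, read by sulforhodamine B assay, with a stated time of 48 h (a higher number here means a weaker inhibitor, a lower number a stronger inhibitor), two compounds with a shared core have numbers so far. Within the data shown here, compound 1 `COc1cc(OC)c(C=C(C(=O)/C=C/c2cccc(OC)c2OC)C(=O)/C=C/c2cccc(OC)c2OC)c(OC)c1` gives 840 nM and compound 2 `COc1cccc(C=C(C(=O)/C=C/c2cccc(OC)c2OC)C(=O)/C=C/c2cccc(OC)c2OC)c1OC` gives 590 nM on this read-out, so compound 2 stands within the scatter of compound 1, its only neighbour. Compound 3 `COc1cc(C=C(C(=O)/C=C/c2cccc(OC)c2OC)C(=O)/C=C/c2cccc(OC)c2OC)cc(OC)c1O` is altered at the same place, on a double-bonded chain carbon bound to a double-bonded chain carbon, with 4-hydroxy-3,5-dimethoxyphenyl in place of 2,3-dimethoxyphenyl on a double-bonded chain carbon bound to a double-bonded chain carbon as its difference from compound 2. Among the measured compounds shown here, the one measured step at that place is a 1.4-fold lower number from compound 1 to compound 2 (0.15 log units; within the scatter) and it stays within the scatter. For the measured compounds named here, no measured compound carries the 4-hydroxy-3,5-dimethoxyphenyl group, so that small step is the only guide, and no step beyond the scatter is expected in this assay here. The estimated step is a 1.1-fold lower number from compound 2 to compound 3 (0.03 log units; within the scatter) and nothing larger is expected. Compound 3 is expected at 550 nM within an estimated range of 220 nM to 1400 nM on this read-out.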

Compound 3, half-maximal inhibitory concentration: 420 nM
For compound 3 the middle estimate is 1.3-fold (0.12 log units) above the measured one; low and high end bracket the measured number.
By their numbers in this assay, from the lowest: compounds 3, 2 and 1 (each within the scatter of the next).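

In this assay, the change to 4-hydroxy-3,5-dimethoxyphenyl gives a 1.4-fold lower number from compound 2 to compound 3 (0.15 log units; within the scatter), and the comparison with the earlier 2,4,6-trimethoxyphenyl compound gives a 2.0-fold lower number from compound 1 to compound 3 (0.30 log units; within the scatter), so all three aryl groups on a double-bonded chain carbon bound to a double-bonded chain carbon now lie within the scatter of one another. Unlike the two groups before it, the entering group carries a hydrogen-bond donor, and this addition produces no step beyond the scatter at this place. No supporting measurement is available to explain how close these numbers lie.

On these data alone, whether an amine, a carboxylic acid or a longer chain at this place would stay in the same range remains open. The rest of the shared core is identical in all three compounds, so they say nothing about changes made elsewhere.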